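Swapping a Methoxyphenyl for a Naphthyl Group

The source may report more compounds than this note shows. Statements on the series, on what has been measured and on what is new or still open speak of the compounds shown alone.

The shared core first appears in compound 1 `c1ccc(-c2cn3ccnc3c(-c3ccc4ncn(C5CCCCC5)c4c3)n2)cc1`, which in a functional assay on HT-29 cells (Homo sapiens) for inhibition, read by sulforhodamine B assay, with a stated time of 48 h, tested at 10 uM (on this read-out lower numbers stand for less inhibition and higher numbers for more inhibition at the one concentration tested (going by the name of the read-out)), gives 48.3%. Within the data shown here, compound 2 `COc1ccc(-c2cn3ccnc3c(-c3ccc4ncn(C5CCCCC5)c4c3)n2)cc1` gives 92.5%, the higher of the two numbers, and the only measured step of a number 44.2 percentage points higher from compound 1 to compound 2 (beyond the scatter) is large. Compound 3 `c1ccc2c(-c3cn4ccnc4c(-c4ccc5ncn(C6CCCCC6)c5c4)n3)cccc2c1` is not yet measured; its change from compound 2 is naphthalen-1-yl in place of 4-methoxyphenyl on an aromatic carbon. Among the measured compounds shown here, that measured step bears only loosely here: no step shows what a second ring brings. A downward step a number 32.5 percentage points lower from compound 2 to compound 3 (beyond the scatter) is nonetheless expected, because the gain a number 44.2 percentage points higher from compound 1 to compound 2 (beyond the scatter) arrived together with the methoxy that now leaves. Compound 3 is estimated at 60%, between 25% and 95%.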

Compound 3, a percentage reported as inhibition, at one concentration (the size of the read-out at that concentration, not a potency): 4.11%
Compound 3: middle estimate off by 55.9 percentage points, on the high side; the whole stated range lies above it.
By their numbers in this assay, from the lowest: compound 3; then compound 1; then compound 2.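

At this position, naphthalen-1-yl in place of 4-methoxyphenyl gives a number 88.4 percentage points lower from compound 2 to compound 3 (beyond the scatter) in this assay. Compared with the plain phenyl, naphthalen-1-yl gives a number 44.2 percentage points lower from compound 1 to compound 3 (beyond the scatter), so losing the methoxy is not the whole story: the two-ring group ends up well under the compound that simply lacks it. Nothing measured here explains this drop.

Still open, as far as these compounds go, is whether a naphthalen-2-yl group would fall as far. From the compounds shown here alone, it is also open whether an amine or a hydroxy group in place of the methoxy would keep the high inhibition of compound 2.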